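Chain shortening at the omega side in the EP3 agonist series

The source may hold more compounds than are shown below. What is called first, only, known or untested is meant among the compounds shown, and "the series" means these compounds.

Compound 1 `O=C(O)c1csc([C@H]2CC[C@@H]3[C@@H](/C=C/[C@@H](O)COc4ccccc4)[C@H](O)C[C@@H]3O2)n1` is the reference of the set: in a functional assay on CHO cells for agonist activity at prostaglandin E2 receptor EP3 subtype (Homo sapiens), read by fluorescence and calcium flux (on this read-out higher numbers stand for an effect only at larger amounts of compound and lower numbers for an effect already at smaller amounts), compound 1 gives 0.8 nM. Compound 2 `O=C(O)c1csc([C@H]2CC[C@@H]3[C@@H](CCCCCOc4ccccc4)[C@H](O)C[C@@H]3O2)n1` carries a saturated chain of five carbons to the phenoxy group; for compound 2 the entry in this assay reads "not determined" (no result reported), so no result has been reported. Compound 3 `O=C(O)c1csc([C@H]2CC[C@@H]3[C@@H](CCCOc4ccccc4)[C@H](O)C[C@@H]3O2)n1` shortens that saturated chain to three carbons, and in this assay compound 3 gives 5800 nM, the highest number among the values shown and far beyond the scatter from compound 1. Compound 4 `O=C(O)c1csc([C@H]2CC[C@@H]3[C@@H](COc4ccccc4)[C@H](O)C[C@@H]3O2)n1` shortens the chain once more: phenoxy in place of 2-phenoxyethyl on a saturated chain carbon bound to a saturated ring carbon. Within the data shown here, no measured step of this kind exists in the set. Compound 3 already sits at the weak end, so the step of a 2.1-fold higher number from compound 3 to compound 4 (0.32 log units; beyond the scatter) is expected to be small or to push the number further up. Compound 4 is estimated at 12000 nM, in the range 2500 nM to 60000 nM.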

Compound 4, half-maximal effective concentration: > 10000 nM
Compound 4 was reported as a limit; the forecaster's own chance of this, stated with the estimate: 35%; the middle value is on the limit's open side.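

In this assay compound 4 gives > 10000 nM, which is a limit of the assay and not a number. Going by these compounds, the step is an at least 1.7-fold higher number from compound 3 to compound 4 (0.23 log units; that floor lies within the scatter), so phenoxy in place of 2-phenoxyethyl at this saturated chain carbon shows no change beyond the scatter, while the true size of the step stays unknown. The reading at this position therefore rests on the assay's ceiling: the limit of > 10000 nM in this assay, at which 1 of the 4 values shown sits.

Open, on these data alone, is how this position would read with an amine in place of the ether oxygen. Also open, as far as these compounds go, is how a chain longer than that of compound 2 would read.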